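A few compounds are considered here, and "the series" means these few. Any claim that something is new, unique, unknown or untested is made for them only; others in the source may bear on it.

Measured compounds:
- Compound 1, `Cc1nc(S(C)(=O)=O)ccc1Oc1ncnc(OC2CCN(C(=O)OC3CCC3)CC2)c1F`: 167 nM
- Compound 2, `Cc1nc(S(C)(=O)=O)ccc1Oc1ncnc(OC2CCN(C(=O)OC(C)(C)C(F)(F)F)CC2)c1F`: 47.2 nM
- Compound 3, `Cc1nc(S(C)(=O)=O)ccc1Oc1ncnc(OC2CCN(C(=O)OC3(C(F)(F)F)CCC3)CC2)c1F`: 63.3 nM

All three were tested in a functional assay on isolated protein for inhibition of Glucose-dependent insulinotropic receptor (Rattus norvegicus), read by HTRF and cAMP accumulation; on this read-out lower numbers stand for an effect already at smaller amounts and higher numbers for an effect only at larger amounts of compound. Compound 2 gives the lowest number of the three, but its gap to compound 3 is within the scatter, so those two cannot be ranked against each other; only compound 1 stands clearly apart from both. Compound 4, `Cc1nc(S(C)(=O)=O)ccc1Oc1ncnc(OC2CCN(C(=O)C(C)(F)F)CC2)c1F`, has not yet been measured. It differs from compound 2 in one place: 1,1-difluoroethyl in place of 1-methyl-1-(trifluoromethyl)ethoxy on a carbonyl carbon.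

The measured steps all swap the group sitting on an oxygen next to a carbonyl group. The step of a 3.5-fold lower number from compound 1 to compound 2 (0.55 log units; beyond the scatter) and the step of a 2.6-fold lower number from compound 1 to compound 3 (0.42 log units; beyond the scatter) show that a trifluoromethyl-bearing group at that position lowers the number modestly, while a 1.3-fold higher number from compound 2 to compound 3 (0.13 log units; within the scatter) shows that two such groups of different shape give much the same number. The change to compound 4 is of another kind: the oxygen itself leaves along with the trifluoromethyl-bearing group, and a smaller 1,1-difluoroethyl enters. Among the measured compounds shown here, no measured step covers this, so the expectation is uncertain and leans on the loss of the feature that helped in the steps from compound 1.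

Compound 4 is therefore expected to give 120 nM in this assay, with a range from 40 nM to 350 nM. This estimate corresponds to an expected step of a 2.5-fold higher number from compound 2 to compound 4 (0.41 log units; beyond the scatter).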

Compound 4, half-maximal effective concentration: 239 nM
Compound 4: the middle estimate sits 2.0-fold (0.30 log units) below what was measured; measured number inside the range.
By their numbers in this assay, from the lowest: compounds 2 and 3 (each within the scatter of the next); then compounds 1 and 4 (each within the scatter of the next).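

Until now only the group on the oxygen had varied; here the oxygen goes too, on a carbonyl carbon whose other neighbour is an amide-type nitrogen in a ring. In this assay, this larger change gives a 5.1-fold higher number from compound 2 to compound 4 (0.70 log units; beyond the scatter) and a 3.8-fold higher number from compound 3 to compound 4 (0.58 log units; beyond the scatter), both clearly beyond the scatter, whereas 1,1-difluoroethyl and cyclobutyloxy on that carbonyl carbon cannot be told apart, with a 1.4-fold higher number from compound 1 to compound 4 (0.16 log units; within the scatter) lying within it, so a group without this oxygen can read the same as one of the oxygen-linked groups. Nothing measured here explains why these numbers move as they do.

As far as these compounds go, the step from compound 2 to compound 4 changes the oxygen, the size of the group and its fluorine count all at once, so the share of each in the rise stays open. From the compounds shown here alone, a 1-methyl-1-(trifluoromethyl)ethyl group placed directly on the carbonyl carbon would separate the oxygen from the rest of the group, and how an amine nitrogen in that oxygen's place would read also remains unknown.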